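Adding a (piperidin-1-yl)methyl group to compound 1

The source may hold more compounds than are shown below. What is called first, only, known or untested is meant among the compounds shown, and "the series" means these compounds.

In a functional assay on the whole organism with Mus musculus as the target (on this read-out higher numbers stand for an effect only at larger amounts of compound and lower numbers for an effect already at smaller amounts), compound 1 `Cc1cc2c(c(C)c1N)CC(C)(C)O2` gives 16.3 mg/kg as its dose. Compound 2 `Cc1cc(N)c(C)c2c1OC(C)(C)C2` gives 32.3 mg/kg in the same test, and these two numbers lie within the usual scatter of each other. Among the compounds with values here, compound 1 therefore stands level with compound 2 among the numbers so far. For compound 3 `Cc1c(C)c2c(c([N+](=O)[O-])c1N)CC(C)(C)O2` the entry > 100 mg/kg is a limit and not a number.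

Attention now turns to compound 4 `Cc1c(N)c(C)c2c(c1CN1CCCCC1)OC(C)(C)C2` and its single difference from compound 1 (piperidin-1-yl)methyl in place of hydrogen on an aromatic carbon in the core. A (piperidin-1-yl)methyl group comes in place of hydrogen on an aromatic carbon, ortho to a fused ring, ortho to a methyl group, meta to an amino group and para to a methyl group.

Within the data shown here, no two measured compounds differ in one place only, so the data give no direct size for such a change. Compound 1 at 16.3 mg/kg is the starting point for the expectation. The estimated step of a 1.5-fold higher number from compound 1 to compound 4 (0.19 log units; within the scatter) is a modest one toward a higher number in this assay and is expected to stay about within the scatter. For compound 4 the estimated dose is 25 mg/kg with an expected range from 8 mg/kg to 80 mg/kg in this test.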

Compound 4, dose for 50% inhibition: > 50 mg/kg
Compound 4: only a limit was reported; the forecaster's own chance of this, stated with the estimate: 20%; at least 2.0-fold (0.30 log units) between middle value and limit.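

In this assay compound 4 is reported as > 50 mg/kg, which is a limit and not a number. Within the data shown here, it still gives the first comparison in this set between two compounds that differ in one place, and that comparison reads as an at least 3.0-fold higher number from compound 1 to compound 4 (0.48 log units; beyond the scatter) for (piperidin-1-yl)methyl in place of hydrogen on an aromatic carbon. So at this position, ortho to a fused ring and meta to an amino group, the new group moves the read-out to a higher number, beyond the scatter, and larger amounts of compound are needed for the effect; the true size of the step stays unknown, since only its lower end is fixed: the limit of > 50 mg/kg in this assay, at which 1 of the 4 values shown sits.

What the compounds shown leave open is whether the change belongs to this particular group or to any substituent on this carbon, since a plain methyl, a dimethylaminomethyl or a morpholin-4-ylmethyl group does not appear among them. They also leave open whether the same (piperidin-1-yl)methyl group would give a comparable step on another aromatic carbon of the shared core.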